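Expecting Compound 3 from Two Measured Analogues

The compounds below may be only part of what the source reports. "The series", "measured", "known", "first", "only" and "open" are said of these compounds alone.

Compound 1 `O=C(NNS(=O)(=O)c1ccc(Cl)cc1Cl)c1cccnc1Nc1ccc(Cl)cc1` gives 44% in a functional assay on MCF7 cells (Homo sapiens) for inhibition, tested at 10 uM; on this read-out higher numbers stand for more inhibition at the one concentration tested (going by the name of the read-out) and lower numbers for less inhibition. Compound 2 `O=C(NNS(=O)(=O)c1ccc(F)cc1)c1cccnc1Nc1ccc(Cl)cc1Cl` stands lowest of the two numbers, giving 0% in this assay, a gap from compound 1 that lies beyond the scatter; the two structures differ in more than one place, so the values alone show this gap. Compound 3 `O=C(NNS(=O)(=O)c1ccc(F)cc1)c1cccnc1Nc1ccc(F)cc1` differs from compound 2 in one place: 4-fluorophenyl in place of 2,4-dichlorophenyl on a nitrogen on an aromatic ring. Within the data shown here, no measured pair isolates this change. The estimated step from compound 2 to compound 3 is a number 10 percentage points higher from compound 2 to compound 3 (within the scatter), expected to be small, upward, and within the scatter. Compound 3 is therefore expected to give 10%, with a range from 0% to 35%.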

Compound 3, a percentage reported as inhibition, at one concentration (the size of the read-out at that concentration, not a potency): 111%
For compound 3 the middle estimate is 101 percentage points below the measured one; measured number above the stated range.
By their numbers in this assay, from the lowest: compound 2; then compound 1; then compound 3.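

In this assay, 4-fluorophenyl in place of 2,4-dichlorophenyl on a nitrogen on an aromatic ring gives a number 111 percentage points higher from compound 2 to compound 3 (beyond the scatter). This single change, which compound 1 and compound 2 could not isolate, shows that the read-out depends strongly on the group at this position. Nothing available explains why the change has so large an effect.

The compounds shown leave open whether the step follows from the two chlorines leaving or the fluorine entering. They also leave open how a phenyl carrying a carboxylic acid or an amine would read at this place.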